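This account rests on a few compounds, and the source may have more. Where it says the series, first, only, none or still open, it means among the compounds named here.

Two numbers exist so far in a functional assay on MCF7 cells (Homo sapiens) for cytotoxicity, read by MTT assay, with a stated time of 72 h; a lower number here means a stronger inhibitor, a higher number a weaker inhibitor: compound 1 `CSc1nc(Cl)c(C(=O)c2ccccc2)s1` gives 91000 nM and compound 2 `O=C(c1ccccc1)c1sc(N2CCCC2)nc1Cl` gives 63000 nM. Going by the values given here, compound 2 therefore stands level with the only other measured compound, and the two cannot be ranked. Compound 3 `O=C(c1ccccc1)c1sc(N2CCCCC2)nc1Cl` carries piperidin-1-yl in place of pyrrolidin-1-yl on an aromatic carbon, next to the ring nitrogen and next to the ring sulfur: piperidin-1-yl in place of pyrrolidin-1-yl on an aromatic carbon. Among the compounds with values here, one measured step bears on this, at the same place but with a different exchange, pyrrolidin-1-yl in place of methylsulfanyl: a 1.4-fold lower number from compound 1 to compound 2 (0.16 log units; within the scatter). That step stays within the scatter, so no step beyond the scatter is expected in this assay, in either direction. The expected change is a 1.1-fold lower number from compound 2 to compound 3 (0.02 log units; within the scatter). Compound 3 is estimated at 60000 nM, with an expected range of 25000 nM to 130000 nM.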

Compound 3, half-maximal inhibitory concentration: 56000 nM
Estimate against measurement, compound 3: 1.1-fold (0.03 log units) above, and the stated range covers the measured number.
By their numbers in this assay, from the lowest: compounds 3, 2 and 1 (each within the scatter of the next).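

In this assay, piperidin-1-yl in place of pyrrolidin-1-yl on the aromatic carbon next to the ring nitrogen and next to the ring sulfur gives a 1.1-fold lower number from compound 2 to compound 3 (0.05 log units; within the scatter), so ring size cannot be separated from scatter for these two groups. Set against methylsulfanyl at the same place, piperidin-1-yl gives a 1.6-fold lower number from compound 1 to compound 3 (0.21 log units; within the scatter), and this step also stays within the scatter. All three groups at this position therefore read alike in this series, and no evidence at hand bears on this result.

Still open, going by these compounds, is whether morpholin-4-yl, an open-chain diethylamino group or a primary amine at this place would depart from these three compounds. Also open, on these data alone, is how the number responds to a methoxy group in place of the chloro group on the shared core.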